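Side-chain variation at the ester-bearing carbon, tail flick

The compounds below may be only part of what the source reports. "The series", "measured", "known", "first", "only" and "open" are said of these compounds alone.

Measured so far:
compound 1 `O=C(CN(c1ncnc2c1ncn2C1CCCCO1)C1CC1)NCC(=O)OCc1ccccc1`: 17.2%
compound 2 `C[C@@H](O)[C@H](NC(=O)CN(c1ncnc2c1ncn2C1CCCCO1)C1CC1)C(=O)OCc1ccccc1`: 10.9%
compound 3 `NC(=O)C[C@H](NC(=O)CN(c1ncnc2c1ncn2C1CCCCO1)C1CC1)C(=O)OCc1ccccc1`: 29.2%

In a functional assay on the whole organism (Tail, strain ICR) with Mus musculus as the target, in the tail flick test, with a stated time of 120 min, at a dose of 25 umol/kg by the oral route (a higher number here means a stronger effect of the compound at the dose given, a lower number a weaker effect), compound 3 stands highest of the three, with a number 12 percentage points higher from compound 1 to compound 3 (beyond the scatter) and a number 18.3 percentage points higher from compound 2 to compound 3 (beyond the scatter) both beyond the scatter, whereas a number 6.3 percentage points lower from compound 1 to compound 2 (within the scatter) stays within it. Compound 4 `N=C(N)NCCC[C@H](NC(=O)CN(c1ncnc2c1ncn2C1CCCCO1)C1CC1)C(=O)OCc1ccccc1` differs from compound 3 by a group of 6 heavy atoms (3 carbon, 3 nitrogen; no ring) in place of a group of 3 heavy atoms (1 carbon, 1 nitrogen, 1 oxygen; no ring), on a saturated chain carbon, two bonds along the chain from an amide-type nitrogen and a carbonyl carbon.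

For the measured compounds named here, no measured step replaces the carbamoyl group by anything, so only the two modest gains that lead into compound 3 bear on this change, and they say nothing about the entering group. The step from compound 3 to compound 4 is therefore expected to be small and uncertain, if anything a fall, as a number 7.2 percentage points lower from compound 3 to compound 4 (within the scatter). Compound 4 is estimated at 22%, within 8% to 38%.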

Compound 4, a percentage reported as activity, at one dose (the size of the read-out at that dose, not a potency): 38.2%
For compound 4 the middle estimate is 16.2 percentage points below the measured one, outside the stated range (above it).
By their numbers in this assay, from the lowest: compounds 2 and 1 (each within the scatter of the next); then compounds 3 and 4 (each within the scatter of the next).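

In this assay, a number 9 percentage points higher from compound 3 to compound 4 (within the scatter) shows that a group of 6 heavy atoms (3 carbon, 3 nitrogen; no ring) can take the place of carbamoyl with no separable difference in the number. Both a number 21 percentage points higher from compound 1 to compound 4 (beyond the scatter) and a number 27.3 percentage points higher from compound 2 to compound 4 (beyond the scatter) put compound 4 clear of the other two side chains, alongside compound 3. No measurement here accounts for these numbers.

From the compounds shown here alone, whether a simple amine or a carboxylic acid at the end of this chain would give a similar number remains open. So does the effect of a longer chain at this place.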